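A few compounds are considered here, and "the series" means these few. Any claim that something is new, unique, unknown or untested is made for them only; others in the source may bear on it.

Series notes, cytotoxicity set.

Measured so far:
- compound 1 `COc1ccc(F)cc1CNCCCNc1ccnc2cc(Cc3ccc(F)cc3)ccc12` gives 3530 nM in an ADME assay on HepG2 cells (Homo sapiens) for cytotoxicity, read by luminescence, CellTiter-Glo and ATP content, with a stated time of 72 h; on this read-out lower numbers stand for an effect already at smaller amounts and higher numbers for an effect only at larger amounts of compound
- compound 2 `COc1ccc(F)cc1CNCCCNc1ccnc2cc(Oc3ccc(F)cc3)ccc12` gives 6600 nM in this assay
- compound 3 `COc1ccc(F)cc1CNCCCNc1ccnc2cc(-c3ccc(C(C)(C)C)cc3)ccc12` gives 620 nM in this assay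

Compound 3 holds the lowest number of the three in this assay. Its nearest neighbour is compound 1, with the step of a 5.7-fold lower number from compound 1 to compound 3 (0.76 log units; beyond the scatter) lying beyond the scatter, and the furthest is compound 2, with an 11-fold lower number from compound 2 to compound 3 (1.03 log units; beyond the scatter) also beyond the scatter. Between compounds 1 and 2 the step of a 1.9-fold higher number from compound 1 to compound 2 (0.27 log units; within the scatter) stays within the scatter, so those two cannot be ordered against each other.

The next compound, compound 4 `COc1ccc(F)cc1CNCCCNc1ccnc2cc(Oc3ccccc3)ccc12`, is not yet measured in this assay. Against compound 3 the change is phenoxy in place of 4-(tert-butyl)phenyl on an aromatic carbon. Among the compounds with values here, two measured steps bear on it. The step of an 11-fold lower number from compound 2 to compound 3 (1.03 log units; beyond the scatter) is the closest analogue, since it exchanges a phenoxy-type group for the 4-(tert-butyl)phenyl, though with a fluorine present on the ring in compound 2 that compound 4 lacks. The step of a 5.7-fold lower number from compound 1 to compound 3 (0.76 log units; beyond the scatter) points the same way, somewhat smaller. Running the change backwards, a clearly higher number is expected for compound 4 in this assay, with the step of a 9.7-fold higher number from compound 3 to compound 4 (0.99 log units; beyond the scatter) expected to sit near the size of the two observed steps, and the value landing close to that of compound 2. Compound 4 is therefore estimated at 6000 nM, within a range of 2500 nM to 14000 nM.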

Compound 4, half-maximal effective concentration: 1500 nM
The estimate for compound 4 lay 4.0-fold (0.60 log units) above the measured number; measured number below the stated range.
By their numbers in this assay, from the lowest: compound 3; then compound 4; then compounds 1 and 2 (each within the scatter of the next).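

Dropping the fluoro from the phenoxy ring is a step in its own right in this assay, with a 4.4-fold lower number from compound 2 to compound 4 (0.64 log units; beyond the scatter) and beyond the scatter, so the number at this position depends on the substituent of the phenoxy ring and not only on the presence of a phenoxy-type group. The large step seen with 4-fluorophenoxy therefore does not carry over to plain phenoxy: a 2.4-fold higher number from compound 3 to compound 4 (0.38 log units; beyond the scatter) is only modest, and the 4-(tert-butyl)phenyl compound keeps the lowest number. Plain phenoxy also separates from 4-fluorobenzyl, with a 2.4-fold lower number from compound 1 to compound 4 (0.37 log units; beyond the scatter) as against a 1.9-fold higher number from compound 1 to compound 2 (0.27 log units; within the scatter) for 4-fluorophenoxy, although this step swaps the bridging atom and removes the fluoro at once, and the two changes cannot be told apart here.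

A plain benzyl group, or a chloro or methoxy group on the phenoxy ring, would show whether the fluoro step holds beyond this one pair and how far it depends on the bridging atom. The data shown contain no measurement that accounts for any of these steps.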